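Swapping the pyridyl of compound 1 for an aminoalkyl chain

This account rests on a few compounds, and the source may have more. Where it says the series, first, only, none or still open, it means among the compounds named here.

Measured compounds:
compound 1, `CC(C)(C)c1ccc(/C(=C/C(=O)Nc2ccc3c(c2)OCCO3)c2cccnc2)cc1`: 510 nM
compound 2, `CC(C)(C)c1ccc(/C(=C/C(=O)Nc2ccc3c(c2)OCCO3)Cc2ccccc2)cc1`: 110 nM

Of the compounds shown here, two have been measured in a functional assay on CHO cells for inhibition of transient receptor potential cation channel subfamily V member 1 (Homo sapiens); on this read-out lower numbers stand for stronger inhibition and higher numbers for weaker inhibition. Compound 1 `CC(C)(C)c1ccc(/C(=C/C(=O)Nc2ccc3c(c2)OCCO3)c2cccnc2)cc1` gives 510 nM, the higher of the two numbers, and compound 2 `CC(C)(C)c1ccc(/C(=C/C(=O)Nc2ccc3c(c2)OCCO3)Cc2ccccc2)cc1` gives 110 nM. Going by the values given here, the one measured step, a 4.6-fold lower number from compound 1 to compound 2 (0.67 log units; beyond the scatter), shows that the group on this chain carbon can be exchanged with a clear effect on the read-out.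

Compound 3 `CN(C)CCC/C(=C\C(=O)Nc1ccc2c(c1)OCCO2)c1ccc(C(C)(C)C)cc1` is not yet measured. It differs from compound 1 as follows: 3-(dimethylamino)propyl in place of pyridin-3-yl on a double-bonded chain carbon bound to an aromatic carbon and a double-bonded chain carbon. Among the compounds with values here, the ring is lost and an open chain takes its place, a change for which no measured step offers a direct parallel; the step from compound 1 to compound 2 only shows that this position responds to substitution. Compound 3 is therefore expected to give a somewhat higher number than compound 1, with wide uncertainty, an expected 2.4-fold higher number from compound 1 to compound 3 (0.37 log units; beyond the scatter). The estimate for compound 3 in this assay is 1200 nM, with an expected range from 250 nM to 6000 nM.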

Compound 3, half-maximal inhibitory concentration: > 4000 nM
Compound 3: no number, only a limit; the forecaster's own chance of this, stated with the estimate: 15%; at least 3.3-fold (0.52 log units) between middle value and limit.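

Compound 3 gives no number in this assay, only a limit: the limit of > 4000 nM in this assay, at which 1 of the 3 values shown sits. The step is an at least 7.8-fold higher number from compound 1 to compound 3 (0.89 log units; beyond the scatter), and measured against the benzyl compound it is an at least 36-fold higher number from compound 2 to compound 3 (1.56 log units; beyond the scatter), so this carbon accepts pyridin-3-yl and benzyl far better than the open 3-(dimethylamino)propyl chain. Pyridin-3-yl and 3-(dimethylamino)propyl match in heavy atoms, hydrogen-bond donors and hydrogen-bond acceptors as counted, so these counts alone do not settle the read-out at this position.

The compounds shown do not separate the loss of the ring from the arrival of the dimethylamino group, which a plain butyl chain or a piperidine ring at this carbon would help to tell apart. The limit also leaves open how large the true step is.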